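Swapping bis(2-hydroxyethyl)amino for (4-chlorophenyl)amino

The source may report more compounds than this note shows. Statements on the series, on what has been measured and on what is new or still open speak of the compounds shown alone.

In an ADME assay on L6 cells (Rattus norvegicus) for cytotoxicity, read by resazurin assay, with a stated time of 70 h (a lower number here means a stronger inhibitor, a higher number a weaker inhibitor), compound 1 `COc1cc(NC(C)CCCNC(=O)Nc2cccc(O)c2)c2ncccc2c1` gives 38 ug/mL and compound 2 `COc1cc(NC(C)CCCNC(=O)NNC(=O)N(CCO)CCO)c2ncccc2c1` gives 79.9 ug/mL, the higher of the two numbers. Compound 3 `COc1cc(NC(C)CCCNC(=O)NNC(=O)Nc2ccc(Cl)cc2)c2ncccc2c1` has (4-chlorophenyl)amino in place of bis(2-hydroxyethyl)amino on a carbonyl carbon. Among the measured compounds shown here, one measured step bears on this: a 2.1-fold higher number from compound 1 to compound 2 (0.32 log units; beyond the scatter), a modest step that removed an aromatic ring. Compound 3 carries such a ring again, so a modest or somewhat larger step in the opposite direction is expected. The expected change is a 2.7-fold lower number from compound 2 to compound 3 (0.43 log units; beyond the scatter) in this assay. For compound 3 the estimate is 30 ug/mL, with an expected range from 10 ug/mL to 65 ug/mL as the likely span.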

Compound 3, half-maximal inhibitory concentration: 43.3 ug/mL
Compound 3: middle estimate off by 1.4-fold (0.16 log units), on the low side; the measured number falls inside the stated range.
By their numbers in this assay, from the lowest: compounds 1, 3 and 2 (each within the scatter of the next, the first and the last beyond it).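

In this assay, (4-chlorophenyl)amino in place of bis(2-hydroxyethyl)amino on a carbonyl carbon gives a 1.8-fold lower number from compound 2 to compound 3 (0.27 log units; within the scatter), so this exchange at this position stays inside the usual scatter. Set against the 3-hydroxyphenyl group on the amide-type nitrogen, ((4-chlorophenyl)carbamoyl)amino gives a 1.1-fold higher number from compound 1 to compound 3 (0.06 log units; within the scatter), so these two aromatic end groups cannot be told apart here. No measurement shown accounts for these numbers. As far as these compounds go, what remains open is how an amine or a carboxylic acid on that carbonyl carbon would read, and whether plain phenylamino would match (4-chlorophenyl)amino.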